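Pyrazole enone series: removing a methoxy from compound 2

The source may report more compounds than this note shows. Statements on the series, on what has been measured and on what is new or still open speak of the compounds shown alone.

Measured so far:
Compound 1 `COc1ccc(-c2cc(/C=C/C(=O)c3ccc(N)cc3)[nH]n2)cc1`: -41%
Compound 2 `COc1cc(-c2cc(/C=C/C(=O)c3ccc(N)cc3)[nH]n2)cc(OC)c1OC`: -66%
Compound 3 `COc1cc(-c2cc(/C=C/C(=O)c3ccc(F)c(F)c3)[nH]n2)cc(OC)c1OC`: 27%

In a functional assay on OVCAR-5 cells (Homo sapiens) for cytotoxicity, read by sulforhodamine B assay, with a stated time of 48 h, tested at 10 uM (a higher number here means a weaker effect of the compound at the concentration tested, a lower number a stronger effect), compound 2 gives the lowest of the three numbers. Compound 1 gives -41% and compound 3 gives 27% in this assay. Among the measured compounds shown here, the only single-site step recorded is a number 93 percentage points higher from compound 2 to compound 3 (beyond the scatter), which replaces 4-aminophenyl with 3,4-difluorophenyl on the carbonyl carbon and does not touch the methoxy-bearing ring.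

Compound 4 `COc1ccc(-c2cc(/C=C/C(=O)c3ccc(N)cc3)[nH]n2)cc1OC` keeps the 4-aminophenyl on the carbonyl carbon and differs from compound 2 at the other ring: hydrogen in place of methoxy on an aromatic carbon. For the measured compounds named here, no measured step concerns a methoxy, so the size of the step in this assay cannot be drawn from the data. Compound 1, which also carries the 4-aminophenyl, shows a number close to that of compound 2, so a modest upward drift at most is expected for compound 4, as a number 11 percentage points higher from compound 2 to compound 4 (beyond the scatter). Compound 4 is estimated at -55%, within -85% to -20%.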

Compound 4, a percentage reported as activity, at one concentration (the size of the read-out at that concentration, not a potency): -10%
Beside the measured number, compound 4's estimate is 45 percentage points below it; the measured number lies above the stated range.
By their numbers in this assay, from the lowest: compound 2; then compound 1; then compound 4; then compound 3.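

In this assay the methoxy-bearing ring proves to be a sensitive site while the 4-aminophenyl stays on the carbonyl carbon: hydrogen in place of methoxy gives a number 56 percentage points higher from compound 2 to compound 4 (beyond the scatter) and is a large change. Methoxy in place of hydrogen at another carbon of that ring gives a number 31 percentage points higher from compound 1 to compound 4 (beyond the scatter) and is also large, so compound 4 stands above both neighbours and the number does not follow the methoxy count across these three compounds.

Open, as far as these compounds go, is whether a hydroxy group or a chlorine on the same aromatic carbon would sit nearer to compound 2 or to compound 4. Also open, from the compounds shown here alone, is whether the methoxy change carries over with 3,4-difluorophenyl on the carbonyl carbon. No measured finding explains either step.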